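A Naphthyl Replacement Tested Against Oesophageal Cancer Cells

The source may report more compounds than this note shows. Statements on the series, on what has been measured and on what is new or still open speak of the compounds shown alone.

Compound 1 `Cc1ccc(Cn2cc(CSc3nnc(-c4ccccc4)c(-c4ccccc4)n3)nn2)cc1` gives 12400 nM in a functional assay on ECa-109 cells for antiproliferative activity against ECa-109 cell line (Homo sapiens), read by MTT assay, with a stated time of 48 h; on this read-out higher numbers stand for weaker inhibition and lower numbers for stronger inhibition. Compound 2 `Fc1ccc(Cn2cc(CSc3nnc(-c4ccccc4)c(-c4ccccc4)n3)nn2)cc1` gives 19100 nM in this assay, and the change a 1.5-fold higher number from compound 1 to compound 2 (0.19 log units; within the scatter) shows that swapping the substituent on the benzyl ring barely moves the read-out. Compound 3 `COc1ccc(C(=O)/C=C/c2ccc(-n3cc(CSc4nnc(-c5ccccc5)c(-c5ccccc5)n4)nn3)cc2)cc1` yields only a limit in this assay, > 100000 nM, so its number is not known; this is the limit of > 100000 nM in this assay, at which 1 of the 3 values shown sits. Among the two real numbers, compound 2 has the larger one, yet compound 1 sits within the scatter of it, so no order between them can be claimed.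

Compound 4 `c1ccc(-c2nnc(SCc3cn(Cc4ccc5ccccc5c4)nn3)nc2-c2ccccc2)cc1` differs from compound 2 by naphthalen-2-yl in place of 4-fluorophenyl on a saturated chain carbon bound to an aromatic nitrogen. Within the data shown here, the only measured step that touches this part of the molecule is the change a 1.5-fold higher number from compound 1 to compound 2 (0.19 log units; within the scatter), which exchanged one small substituent on that benzyl ring for another and stayed within the scatter. Among the measured compounds shown here, no measured pair shows what happens when the whole ring is enlarged to a second fused ring, so the evidence supports neither a gain nor a loss beyond the scatter. Compound 4 is therefore expected to land near compound 2, with an estimated step of a 1.3-fold lower number from compound 2 to compound 4 (0.10 log units; within the scatter) and an estimated value of 15000 nM, between 5000 nM and 60000 nM.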

Compound 4, half-maximal inhibitory concentration: > 100000 nM
Compound 4 ended at the assay's limit; the forecaster's own chance of this, stated with the estimate: 10%; middle value at least 6.6-fold (0.82 log units) from the limit.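

Until compound 4, this position had shown only a swap of small groups on the benzyl ring, a 1.5-fold higher number from compound 1 to compound 2 (0.19 log units; within the scatter). Placing naphthalen-2-yl on the saturated chain carbon bound to an aromatic nitrogen has a far larger effect in this assay: in place of 4-fluorophenyl it gives an at least 5.2-fold higher number from compound 2 to compound 4 (0.71 log units; beyond the scatter), and in place of 4-methylphenyl it gives an at least 8.0-fold higher number from compound 1 to compound 4 (0.90 log units; beyond the scatter). The position is therefore not indifferent to what it carries, since the two single-ring groups give measurable numbers while the second fused ring moves the read-out towards weaker inhibition, and the result for compound 4 is a limit and not a number, so these steps fix only the smallest possible size of the loss: the limit of > 100000 nM in this assay, at which 2 of the 4 values shown sit.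

On these data alone, it remains open whether a cyclohexyl group, a longer chain or an amine at this position would keep a measurable number, or whether the loss begins only with the full naphthalen-2-yl group. As far as these compounds go, it is also open whether the same change would cost as much on a core other than that of compound 1.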